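A few compounds are considered here, and "the series" means these few. Any claim that something is new, unique, unknown or untested is made for them only; others in the source may bear on it.

Measured in an ADME assay on cells (Hepatocyte, Mus musculus) for metabolic stability, with a stated time of 30 min; on this read-out higher numbers stand for a more stable compound and lower numbers for a less stable compound:
compound 1 `CS(=O)(=O)NC1CCC(CN2CCN(c3cc(=O)c4cc(C(F)(F)F)cc([N+](=O)[O-])c4s3)CC2)CC1`: 111%
compound 2 `O=C(OC1CCC(CN2CCN(c3cc(=O)c4cc(C(F)(F)F)cc([N+](=O)[O-])c4s3)CC2)CC1)c1ccncc1`: 1.4%
compound 3 `Nc1cc(C(F)(F)F)cc2c(=O)cc(N3CCN(CC4CCC(O)CC4)CC3)sc12`: 60%

Compound 2, at 1.4%, stands lowest of the three, well under both compound 3 and compound 1. Compound 4 `O=C(OC1CCC(CN2CCN(c3cc(=O)c4cc(C(F)(F)F)cc([N+](=O)[O-])c4s3)CC2)CC1)C1CCCCC1` has cyclohexyl in place of pyridin-4-yl on a carbonyl carbon. Going by the values given here, only one measured step bears on this: a number 109.6 percentage points lower from compound 1 to compound 2 (beyond the scatter), a large drop that came with ((pyridin-4-yl)carbonyl)oxy in place of methanesulfonamido on a saturated ring carbon. Among the compounds with values here, compound 4 keeps the carbonyl and its oxygen and swaps only the ring on the carbonyl carbon, a swap no measured pair tests. Little movement in this assay is therefore expected, probably none beyond the scatter. The expected change is a number 3.6 percentage points higher from compound 2 to compound 4 (within the scatter). The estimated value for compound 4 is 5%, with an expected range of 0.5% to 25%.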

Compound 4, percent of the compound remaining: 1.2%
Estimate against measurement, compound 4: 3.8 percentage points above, and the stated range covers the measured number.
By their numbers in this assay, from the lowest: compounds 4 and 2 (each within the scatter of the next); then compound 3; then compound 1.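

In this assay, cyclohexyl in place of pyridin-4-yl on the carbonyl carbon gives a number 0.2 percentage points lower from compound 2 to compound 4 (within the scatter), so the number stays low with either ring at this position. The large drop also holds with the new ring, as a number 109.8 percentage points lower from compound 1 to compound 4 (beyond the scatter) shows, so it is not tied to pyridin-4-yl. Nothing available explains why these numbers are low.

Still open, from the compounds shown here alone, is whether the low number goes with the carbonyl and its oxygen themselves. An amide link on the saturated ring carbon, or an open-chain alkyl group on the carbonyl carbon, could test this.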